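A few compounds are considered here, and "the series" means these few. Any claim that something is new, unique, unknown or untested is made for them only; others in the source may bear on it.

Of the compounds shown here, three sharing a core have been measured in a functional assay (plasma) for inhibition, with Homo sapiens as the target; a lower number here means a stronger inhibitor, a higher number a weaker inhibitor. Compound 1 `O=C(O)CCC/C=C\CC1C2CCC(O2)C1/C=C/[C@@H](O)CCc1ccccc1` gives 1200 nM and compound 2 `C[C@@H](c1ccc(O)c(I)c1)[C@H](O)/C=C/C1C2CCC(O2)C1C/C=C\CCCC(=O)O` gives 930 nM, which amounts to a 1.3-fold lower number from compound 1 to compound 2 (0.11 log units; within the scatter). Compound 3 `CC(CC/C=C\C[C@H]1C2CCC(O2)[C@H]1/C=C/[C@@H](O)[C@@H](C)c1ccccc1)C(=O)O` gives 25000 nM, the highest of the three numbers and beyond the scatter of both others, so it is the weakest inhibitor of the set.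

Compound 4 `C[C@@H](c1ccccc1)[C@H](O)/C=C/[C@@H]1C2CCC(O2)[C@@H]1CC/C=C/CCC(=O)O` changes the acid-bearing chain of compound 3: 5-carboxypent-2-en-1-yl in place of 5-carboxyhex-1-en-1-yl on a saturated chain carbon bound to a saturated ring carbon. Here 5-carboxypent-2-en-1-yl stands in place of 5-carboxyhex-1-en-1-yl on a saturated chain carbon bound to a saturated ring carbon.

Among the compounds with values here, no measured step touches this chain. The only one available, a 1.3-fold lower number from compound 1 to compound 2 (0.11 log units; within the scatter), concerns a different group and stays within the scatter, so it offers no size to carry over. Among the measured compounds, the departing 5-carboxyhex-1-en-1-yl occurs only in compound 3, while the entering group has not been measured at all. The lower numbers of compound 1 at 1200 nM and compound 2 at 930 nM suggest a partial fall in this assay, though with wide uncertainty. The expected change is a 5.0-fold lower number from compound 3 to compound 4 (0.70 log units; beyond the scatter). For compound 4 the estimate is 5000 nM, with an expected range from 1000 nM to 25000 nM.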

Compound 4, half-maximal inhibitory concentration: 25000 nM
Compound 4: the middle estimate sits 5.0-fold (0.70 log units) below what was measured; measured number inside the range.
By their numbers in this assay, from the lowest: compounds 2 and 1 (each within the scatter of the next); then compounds 3 and 4 (each within the scatter of the next).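

In this assay, placing 5-carboxypent-2-en-1-yl in place of 5-carboxyhex-1-en-1-yl, on a saturated chain carbon bound to a saturated ring carbon, gives no change at the digits printed from compound 3 to compound 4 (within the scatter). Within the data shown here, this is the first measured step on the acid-bearing chain, and it shows that this swap, with the double-bond count and the hydrogen-bond donor and acceptor counts unchanged, leaves the number where it was, so this particular swap does not by itself lift compound 3 out of its weak standing. Nothing measured here accounts for that lack of change, and no independent data bear on it.

Going by these compounds, whether a longer chain ending in the same acid, or a chain ending in a primary amide, would shift the number at this place remains open. On these data alone, it is also open whether this swap would leave the number equally unchanged on the background of compound 2, which carries an iodine and a hydroxyl group on its aromatic ring.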